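The compounds below may be only part of what the source reports. "The series", "measured", "known", "first", "only" and "open" are said of these compounds alone.

Measured compounds:
- compound 1, `CNCC(=O)Nc1cc(OC)ccc1C(=O)c1ccc2c(c1)C=CC(C)(C)O2`, in a functional assay on HCT-8 cells (Homo sapiens) for antiproliferative activity, read by MTT assay, with a stated time of 48 h (on this read-out lower numbers stand for stronger inhibition and higher numbers for weaker inhibition), gives 1010 nM
- compound 2, `CCNCC(=O)Nc1cc(OC)ccc1C(=O)c1ccc2c(c1)C=CC(C)(C)O2`, gives 3990 nM
- compound 3, `C=C(c1cc(OC)c(OC)c(OC)c1)c1ccc(OC)cc1NC(=O)CNC`, gives 190 nM

Compound 1 and compound 2 share a core and differ in one place: methyl in place of hydrogen on a saturated chain carbon bound to an amine nitrogen. That change produced a 4.0-fold higher number from compound 1 to compound 2 (0.60 log units; beyond the scatter). Compound 3 sits on a different core; how the two cores differ is not broken down here. Its value in this assay is the lowest of the three, and the steps from compound 1 and from compound 2 to compound 3 both lie beyond the scatter.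

Compound 4, `C=C(c1cc(OC)c(OC)c(OC)c1)c1ccc(OC)cc1NC(=O)CNCC`, has not yet been measured. It differs from compound 3 by methyl in place of hydrogen on a saturated chain carbon bound to an amine nitrogen, which is the same change that separates compound 1 from compound 2, made on the core of compound 3. A step of about a 3.9-fold higher number from compound 3 to compound 4 (0.60 log units; beyond the scatter) is expected in this assay, resting on the step of a 4.0-fold higher number from compound 1 to compound 2 (0.60 log units; beyond the scatter) seen on the other core; whether a change carries over between cores is not shown by the three measured compounds, so the range is kept wide. Compound 4 is estimated at 750 nM, between 300 nM and 2000 nM.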

Compound 4, half-maximal inhibitory concentration: 590 nM
Compound 4: the middle estimate sits 1.3-fold (0.10 log units) above what was measured, within the range that was stated.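

In this assay, methyl in place of hydrogen on a saturated chain carbon bound to an amine nitrogen again raised the number on the core of compound 3, giving a 3.1-fold higher number from compound 3 to compound 4 (0.49 log units; beyond the scatter). Set beside the earlier step on the other core, the two agree: the same change on two cores in this assay, a 4.0-fold higher number (0.60 log units; beyond the scatter) from compound 1 to compound 2 and a 3.1-fold higher number (0.49 log units; beyond the scatter) from compound 3 to compound 4, 1.3-fold (0.10 log units) apart, within the scatter of two such steps. This shows that the change from methylamino to ethylamino carried over between these cores at much the same size, but it rests on a single pair on each core in one cell assay, so it does not show that the step would hold on any further core, nor does it say why the step has this size.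

The compounds shown leave open whether a longer chain on the amine, such as propyl, or a branched one, such as isopropyl, would continue the same trend on either core. They also leave open how a primary amine or a dimethylamino group would compare with methylamino and ethylamino.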